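The source may hold more compounds than are shown below. What is called first, only, known or untested is meant among the compounds shown, and "the series" means these compounds.

Measured so far:
- compound 1 `CCC(=O)N1CCc2cc(CNC(=O)c3ccccc3)ccc21`: 87%
- compound 2 `CCC(=O)N1CCc2cc(CNC(=O)c3ccc(F)cc3)ccc21`: 96%

Both compounds share one core, a propanoyl-bearing bicyclic amine carrying a methylene-amide link to a benzene ring, and were tested in an assay on HEK293 cells for inhibition of Indoleamine 2,3-dioxygenase 1 (Homo sapiens), tested at 10 uM; on this read-out lower numbers stand for less inhibition and higher numbers for more inhibition at the one concentration tested (going by the name of the read-out). Compound 2 sits at 96%, and the step of a number 9 percentage points higher from compound 1 to compound 2 (within the scatter) leaves the two compounds indistinguishable on this read-out.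

Compound 3 `CCC(=O)N1CCc2cc(CNC(=O)c3cccc(Cl)c3)ccc21` is not yet measured. It differs from compound 2 in one place: 3-chlorophenyl in place of 4-fluorophenyl on a carbonyl carbon.

Going by the values given here, only one measured step bears on this change, and only loosely: a number 9 percentage points higher from compound 1 to compound 2 (within the scatter), which also alters the same benzene ring and stays within the scatter. Among the compounds with values here, no measured step tells what swapping a fluorine for a chlorine, or moving a halogen on that ring, does here, and both compounds already give high numbers, leaving little room upward. The expected step of a number 10 percentage points lower from compound 2 to compound 3 (within the scatter) is therefore no change beyond the scatter. Compound 3 is estimated to give 86%, with a range from 65% to 98%.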

Compound 3, a percentage reported as inhibition, at one concentration (the size of the read-out at that concentration, not a potency): 77%
Compound 3: the middle estimate sits 9 percentage points above what was measured, within the range that was stated.
By their numbers in this assay, from the lowest: compounds 3, 1 and 2 (each within the scatter of the next, the first and the last beyond it).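

In this assay, going by these compounds alone, the ring on the carbonyl carbon does respond to what it carries: 3-chlorophenyl in place of 4-fluorophenyl gives a number 19 percentage points lower from compound 2 to compound 3 (beyond the scatter) and is the first step in this small set that clears the usual scatter. That gap shows only between the two halogen-bearing compounds, since each stays close to the unsubstituted phenyl of compound 1: the fluoro group gives a number 9 percentage points higher from compound 1 to compound 2 (within the scatter) and the chloro group gives a number 10 percentage points lower from compound 1 to compound 3 (within the scatter) so neither halogen can be said to differ from hydrogen on its own. Nothing available here explains why this swap lowers the number.

The swap changes both the halogen and its place on the ring in one move, so these compounds cannot say which of the two accounts for the gap, and 3-fluorophenyl or 4-chlorophenyl would separate them. Also open, going by these compounds, is how the same position responds to a group other than a halogen, such as a methoxy group, an amine or a carboxylic acid.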